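The source may report more compounds than this note shows. Statements on the series, on what has been measured and on what is new or still open speak of the compounds shown alone.

Measured so far:
Compound 1 `COc1cccc(Cn2cc(-c3ccc(OC)c(OC)c3OC)nn2)c1` — in a functional assay on B16 cells (Mus musculus) for cytotoxicity, read by MTT assay, with a stated time of 48 h (on this read-out higher numbers stand for weaker inhibition and lower numbers for stronger inhibition), compound 1 reaches only the limit of the assay, > 100000 nM, not a number.
Compound 2 `COc1ccc(C(O)c2cn(C[C@H]3COC(C)(C)O3)nn2)c(OC)c1OC` — in this assay compound 2 likewise gives only the limit > 100000 nM.
Compound 3 `COc1ccc(-c2cn(C[C@H]3COC(C)(C)O3)nn2)c(OC)c1OC` — in this assay compound 3 also stops at the limit > 100000 nM.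

The change from compound 3 to compound 1 is 3-methoxyphenyl in place of 2,2-dimethyl-1,3-dioxolan-4-yl on a saturated chain carbon bound to an aromatic nitrogen, and its step that the two limits leave unreadable from compound 3 to compound 1 cannot be read because of the limit of > 100000 nM in this assay, at which 3 of the 3 values shown sit. Compound 4 `COc1cccc(Cn2cc(C(O)c3ccc(OC)c(OC)c3OC)nn2)c1` arises from compound 2 by 3-methoxyphenyl in place of 2,2-dimethyl-1,3-dioxolan-4-yl on a saturated chain carbon bound to an aromatic nitrogen, the same change at the same place; the difference between the cores of compound 2 and compound 3 is not broken down here. Since both measured ends sit at the limit, no size is known for this change, and compound 4 is expected to stay near the limit too, an estimated step that the limit leaves unreadable from compound 2 to compound 4. Compound 4 is therefore estimated at 150000 nM, between 50000 nM and 500000 nM.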

Compound 4, half-maximal inhibitory concentration: > 100000 nM
Compound 4: a limit, no number; the forecaster's own chance of this, stated with the estimate: 85%; the middle value does not contradict the limit.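

No step can be read from compound 2 to compound 4, because both stop at a limit of the assay rather than a number: the limit of > 100000 nM in this assay, at which 4 of the 4 values shown sit.

How strongly any of these compounds acts, and whether 3-methoxyphenyl in place of 2,2-dimethyl-1,3-dioxolan-4-yl changes that at all, stays open.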